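Sulfonate esters of an anilide series: antiproliferative readings

A few compounds are considered here, and "the series" means these few. Any claim that something is new, unique, unknown or untested is made for them only; others in the source may bear on it.

Measured so far:
compound 1, `CC(C)c1ccccc1OS(=O)(=O)c1ccc(NC(=O)C(C)(C)C)cc1`: 15000 nM
compound 2, `CC(C)(C)C(=O)Nc1ccc(S(=O)(=O)Oc2ccccc2I)cc1`: 9500 nM
compound 3, `CC(C)c1ccccc1OS(=O)(=O)c1ccc(NC(=O)CCl)cc1`: 5600 nM

All three were read in a functional assay on HT-29 cells (Homo sapiens) for antiproliferative activity, read by sulforhodamine B assay, with a stated time of 48 h; a lower number here means a stronger inhibitor, a higher number a weaker inhibitor. Two changes have been made to compound 1. One is iodo in place of isopropyl on an aromatic carbon; it gave a 1.6-fold lower number from compound 1 to compound 2 (0.20 log units; within the scatter). The other is chloromethyl in place of tert-butyl on a carbonyl carbon; it gave a 2.7-fold lower number from compound 1 to compound 3 (0.43 log units; beyond the scatter), and compound 3 thereby carries the lowest of the three numbers, though its gap to compound 2 is within the scatter.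

Compound 4, `O=C(CCl)Nc1ccc(S(=O)(=O)Oc2ccccc2I)cc1`, is not yet measured in this assay. It stands to compound 3 as compound 2 stands to compound 1: the difference is iodo in place of isopropyl on an aromatic carbon. The cores of the two pairs differ as given above for compound 1 and compound 3, namely in what sits on the carbonyl carbon of the amide. The place of the exchanged group is described in the same words for both pairs, so the change is taken as the same one, now made on the core of compound 3 instead of that of compound 1.

Going by the values given here, the only precedent for this change is the step from compound 1 to compound 2, which lay within the scatter. On that basis the step to compound 4 is expected to be small as well, about a 1.4-fold lower number from compound 3 to compound 4 (0.15 log units; within the scatter), resting on a 1.6-fold lower number from compound 1 to compound 2 (0.20 log units; within the scatter) applied to compound 3 at 5600 nM. Compound 4 is therefore estimated at 4000 nM in this assay, with a likely range from 1500 nM to 10000 nM.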

Compound 4, half-maximal inhibitory concentration: 4100 nM
Estimate against measurement, compound 4: 1.0-fold (0.01 log units) below; low and high end bracket the measured number.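

Iodo in place of isopropyl on an aromatic carbon gave a 1.4-fold lower number from compound 3 to compound 4 (0.14 log units; within the scatter) in this assay, and this reading agrees with the one on the other core: the same change on two cores in this assay, a 1.6-fold lower number (0.20 log units; within the scatter) from compound 1 to compound 2 and a 1.4-fold lower number (0.14 log units; within the scatter) from compound 3 to compound 4, 1.2-fold (0.06 log units) apart, within the scatter of two such steps

Chloromethyl in place of tert-butyl on a carbonyl carbon gave a 2.3-fold lower number from compound 2 to compound 4 (0.36 log units; beyond the scatter) in this assay, and this change also repeats across cores: the same change on two cores in this assay, a 2.7-fold lower number (0.43 log units; beyond the scatter) from compound 1 to compound 3 and a 2.3-fold lower number (0.36 log units; beyond the scatter) from compound 2 to compound 4, 1.2-fold (0.06 log units) apart, within the scatter of two such steps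

Across these four compounds, each change therefore carries from one core to the other with no detectable difference in step size, but this rests on only two cores per change. Both iodo steps lie within the scatter. Going by these compounds alone, they show no clear effect of that exchange, only that the two readings agree, while the chloromethyl steps are modest.

From the compounds shown here alone, it remains open whether the same carry-over would hold for other groups on that aromatic carbon, such as bromo, methoxy or a tert-butyl group, or for other groups on the carbonyl carbon, such as a bromomethyl group, an aminomethyl group or a longer alkyl chain. The compounds shown also leave open whether a larger step, one clearly beyond the scatter, would transfer between cores as closely as these modest ones do.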